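The source may hold more compounds than are shown below. What is called first, only, known or untested is meant among the compounds shown, and "the series" means these compounds.

Half-lives in an ADME assay on microsomes from liver (Homo sapiens) for metabolic stability; a higher number here means that the compound lasts longer, a lower number that the compound disappears faster:
- compound 1 `COc1cc(OCc2csc(-c3ccc(C(F)(F)F)cc3)n2)c2cc(-c3cn4nc(OC)sc4n3)oc2c1`: > 2 h (a limit, not a number)
- compound 2 `COc1cc(OCc2cccc(-c3ccc(OC)nc3)c2)c2cc(-c3cn4nc(OC)sc4n3)oc2c1`: 0.733 h
- compound 3 `COc1cc(OCc2cccc(-c3cnc(OC)cn3)c2)c2cc(-c3cn4nc(OC)sc4n3)oc2c1`: 1.48 h

Compound 1 is reported only as a limit, which puts compound 1 at the limit of > 2 h in this assay, at which 1 of the 3 values shown sits, and gives no exact starting point.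

The next compound to be measured is compound 4 `COc1cc(OCc2csc(-c3ccc(C(N)=O)cc3)n2)c2cc(-c3cn4nc(OC)sc4n3)oc2c1`, where 4-(trifluoromethyl)phenyl becomes 4-carbamoylphenyl: carbamoyl in place of trifluoromethyl on an aromatic carbon. Among the compounds with values here, no measured step touches this group. The only one available is a 2.0-fold higher number from compound 2 to compound 3 (0.31 log units; beyond the scatter), a modest step that places 5-methoxypyrazin-2-yl where 6-methoxypyridin-3-yl stood, so it serves only as a rough guide to size. Its size gives no reason to expect a large change, and no direction can be read from it, so no step beyond the scatter is expected in this assay. The estimated change is an at least 1.1-fold lower number from compound 1 to compound 4 (0.04 log units; that floor lies within the scatter) as a working figure. Compound 4 is expected at about 1.8 h in this read-out, with an estimated range from 0.8 h to 4 h and a real chance of another limit.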

Compound 4, half-life: 1.38 h
Compound 4: middle estimate off by 1.3-fold (0.12 log units), on the high side; measured number inside the range.
By their numbers in this assay, from the lowest: compounds 2, 4 and 3 (each within the scatter of the next, the first and the last beyond it). At a limit, above all of these: compound 1.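

In this assay, within the data shown here, the only step at this position, 4-(trifluoromethyl)phenyl to 4-carbamoylphenyl, gives an at least 1.4-fold lower number from compound 1 to compound 4 (0.16 log units; that floor lies within the scatter). Compound 4, at 1.38 h, gives this part of the series its first exact value, against which further changes at this position can be read. Compound 1 stands at a limit and not at a number, so only a floor for this step can be read: the limit of > 2 h in this assay, at which 1 of the 4 values shown sits.

Going by these compounds, how far compound 1 lies past its limit, and so whether the true step goes beyond the scatter, remains open. On these data alone, whether a carboxylic acid, a nitrile or an amine in the same place would give a half-life close to that of compound 4 is also open, since a single pair shows no trend.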